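Adding a Second Chloro to the Benzyl Arm

The compounds below may be only part of what the source reports. "The series", "measured", "known", "first", "only" and "open" are said of these compounds alone.

Measured so far, in a functional assay on HeLa cells (Homo sapiens) for antiproliferative activity, read by MTT assay, with a stated time of 48 h, in the presence of a further agent that is not named here; a lower number here means a stronger inhibitor of growth, a higher number a weaker inhibitor of growth:
compound 1, `COc1ccc(-c2nn(-c3ccccc3)cc2C(=O)NOCc2ccccc2Cl)cc1`, gives 3480 nM
compound 2, `COc1ccc(-c2nn(-c3ccccc3)cc2C(=O)NOCc2ccc(Cl)cc2Cl)cc1`, gives 5750 nM
compound 3, `O=C(NOCc1ccccc1Cl)c1cn(-c2ccccc2)nc1-c1ccc(Cl)cc1`, gives 8850 nM

Compound 4, `O=C(NOCc1ccc(Cl)cc1Cl)c1cn(-c2ccccc2)nc1-c1ccc(Cl)cc1`, has not been measured. It is reached from compound 3 by the change (chloro in place of hydrogen on an aromatic carbon). The same change has already been made once, from compound 1 to compound 2, where it is chloro in place of hydrogen on an aromatic carbon, and the outcome there was a 1.7-fold higher number from compound 1 to compound 2 (0.22 log units; within the scatter). The two "place" descriptions are identical word for word, so this is the same change made on a different core. The two cores differ by chloro in place of methoxy on an aromatic carbon, and that difference on its own gave a 2.5-fold higher number from compound 1 to compound 3 (0.41 log units; beyond the scatter).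

For the measured compounds named here, with only one earlier instance to lean on, the expectation for compound 4 is that the step of a 1.5-fold higher number from compound 3 to compound 4 (0.17 log units; within the scatter) will be about the size seen before, because compound 1 to compound 2 gave a 1.7-fold higher number from compound 1 to compound 2 (0.22 log units; within the scatter), a shift that stayed within the scatter. Compound 4 is therefore estimated at 13000 nM in this assay, with a plausible range from 6000 nM to 30000 nM.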

Compound 4, concentration for 50% growth inhibition: 5160 nM
Compound 4: middle estimate off by 2.5-fold (0.40 log units), on the high side, outside the stated range (below it).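

In this assay, turning 2-chlorobenzyl into 2,4-dichlorobenzyl on the chloro core gave a 1.7-fold lower number from compound 3 to compound 4 (0.23 log units; within the scatter), so this change does not carry over as a fixed step between the two cores: the same change on two cores in this assay, a 1.7-fold higher number (0.22 log units; within the scatter) from compound 1 to compound 2 and a 1.7-fold lower number (0.23 log units; within the scatter) from compound 3 to compound 4, 2.8-fold (0.45 log units) apart, beyond the scatter of two such steps Exchanging methoxy for chloro on the core likewise depends on the benzyl arm, since with the 2,4-dichlorobenzyl arm it gave a 1.1-fold lower number from compound 2 to compound 4 (0.05 log units; within the scatter): the same change on two cores in this assay, a 2.5-fold higher number (0.41 log units; beyond the scatter) from compound 1 to compound 3 and a 1.1-fold lower number (0.05 log units; within the scatter) from compound 2 to compound 4, 2.8-fold (0.45 log units) apart, beyond the scatter of two such steps Each chloro-for-hydrogen step alone stays within the scatter, so the data do not show that the second chloro helps on one core or harms on the other, and four compounds give no cause for the mismatch.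

The compounds shown leave open whether a fluoro, a methyl or an amine in place of the added chloro would also behave differently on the two cores. They also leave open what happens on a core carrying a nitrile or a carboxylic acid in place of the methoxy or chloro.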